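Sulfonyl aryl replacement in the trifluoromethyl hydroxyamide series

The source may report more compounds than this note shows. Statements on the series, on what has been measured and on what is new or still open speak of the compounds shown alone.

Compound 1 `CC(O)(C(=O)Nc1ccc(S(=O)(=O)c2ccc(F)cc2)cc1)C(F)(F)F` gives 8600 nM in a functional assay (Cavia porcellus) with sulfonylurea receptors; K-ATP channels (Homo sapiens) as the target; on this read-out higher numbers stand for weaker inhibition and lower numbers for stronger inhibition. Compound 3 `CC(O)(C(=O)Nc1ccc(C(=O)c2ccccc2)cc1O)C(F)(F)F` gives 15000 nM in this assay; the two values sit within the scatter of each other, so no order between them is claimed. For compound 2 `CC(O)(C(=O)Nc1ccc(S(=O)(=O)N(c2ccccc2)c2ccccc2)cc1)C(F)(F)F` this assay reports only a limit, > 30000 nM. the limit of > 30000 nM in this assay, at which 1 of the 3 values shown sits, is the sole limit among the three values. Compound 4 `CC(O)(C(=O)Nc1ccc(S(=O)(=O)c2nccs2)cc1)C(F)(F)F` has not been measured in this assay; it differs from compound 1 in one place: 1,3-thiazol-2-yl in place of 4-fluorophenyl on a sulfonyl sulfur. Within the data shown here, no measured pair in the set isolates this kind of change, so the expected step is small, in neither direction beyond the scatter. The expected step of a 1.2-fold higher number from compound 1 to compound 4 (0.07 log units; within the scatter) is set near zero. Compound 4 is estimated at 10000 nM, with a range from 3000 nM to 30000 nM.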

Compound 4, half-maximal inhibitory concentration: 1400 nM
Compound 4: middle estimate off by 7.1-fold (0.85 log units), on the high side; measured number outside the range, below it.
By their numbers in this assay, from the lowest: compound 4; then compounds 1 and 3 (each within the scatter of the next). At a limit, above all of these: compound 2.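

In this assay, among these compounds, the group on the sulfonyl sulfur emerges as a position that can move the read-out, with 1,3-thiazol-2-yl in place of 4-fluorophenyl giving a 6.1-fold lower number from compound 1 to compound 4 (0.79 log units; beyond the scatter) as the only step read so far. The five-membered ring with 2 hetero atoms replaces the six-membered ring of carbon only, so several features change at once. No measurement shown bears on the reason for this step.

Which of these features carries the step stays open. A pyridin-2-yl or thiophen-2-yl group on the sulfonyl sulfur, or an amine on the thiazole ring, would test this further.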